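A few compounds are considered here, and "the series" means these few. Any claim that something is new, unique, unknown or untested is made for them only; others in the source may bear on it.

Measured so far:
compound 1 `O=S(=O)(NCCCNCc1ccc(C(F)(F)F)cc1)c1cc(C(F)(F)F)cc(C(F)(F)F)c1` gives 2000 nM;
compound 2 `O=S(=O)(NCCCNCc1ccccc1)c1cc(C(F)(F)F)cc(C(F)(F)F)c1` gives 14000 nM;
compound 3 `O=S(=O)(NCCCNCc1ccc(Br)cc1)c1cc(C(F)(F)F)cc(C(F)(F)F)c1` gives 2000 nM.

In a functional assay on Capan-2 cells (Homo sapiens) for inhibition, read by MTT assay, with a stated time of 72 h (on this read-out lower numbers stand for stronger inhibition of growth and higher numbers for weaker inhibition of growth), compound 3 stands level with compound 1, the two sharing the lowest numbers of the three, while a 7.0-fold lower number from compound 2 to compound 3 (0.85 log units; beyond the scatter) separates it from compound 2. Compound 4 `O=S(=O)(NCCCNCc1ccc(-c2ccccc2)cc1)c1cc(C(F)(F)F)cc(C(F)(F)F)c1` arises through (phenyl in place of bromo on an aromatic carbon). Going by the values given here, the steps that bear on this site are no change at the digits printed from compound 1 to compound 3 (within the scatter) and a 7.0-fold lower number from compound 2 to compound 3 (0.85 log units; beyond the scatter): bromo and trifluoromethyl give the same number, and only hydrogen at this carbon gives a weaker result. Among the compounds with values here, no measured step shows a phenyl here, so the size of the change is uncertain. Compound 4 is expected to give about 2000 nM in this assay, within 600 nM to 7000 nM. That estimate means an expected no change at the digits printed from compound 3 to compound 4 (within the scatter).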

Compound 4, concentration for 50% growth inhibition: 2200 nM
For compound 4 the middle estimate is 1.1-fold (0.04 log units) below the measured one; measured number inside the range.
By their numbers in this assay, from the lowest: compounds 1, 3 and 4 (each within the scatter of the next); then compound 2.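

In this assay the step of a 1.1-fold higher number from compound 3 to compound 4 (0.04 log units; within the scatter) and the step of a 1.1-fold higher number from compound 1 to compound 4 (0.04 log units; within the scatter) show that phenyl, with 6 heavy atoms and a ring of its own, sits level with bromo and trifluoromethyl on this aromatic carbon. The step of a 6.4-fold lower number from compound 2 to compound 4 (0.80 log units; beyond the scatter) shows that it also stands apart from hydrogen, as the other two groups do. No evidence is given that would explain this result.

The compounds shown leave open whether a group bearing an amine or a carboxylic acid at this carbon would stay at this level. They also leave open whether a longer chain there would do so.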